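Swapping a Fluorophenyl for a Cyclohexyl Ring

This account rests on a few compounds, and the source may have more. Where it says the series, first, only, none or still open, it means among the compounds named here.

Three compounds sharing one core have been run through an ADME assay on Caco-2 cells (Homo sapiens) for permeability, read by LC-MS, in the apical to basolateral direction, with a stated time of 60 min, at pH 6.5; on this read-out lower numbers stand for lower permeability and higher numbers for higher permeability. Compound 1 `O=C(NCc1cc(Cl)ccc1-n1cnnn1)[C@@H]1C[C@@H]2C[C@@H]2N1C(=O)[C@H](O)Cn1cccn1` gives 0.45 10^-6 cm/s. Compound 2 `O=C(NCc1cc(Cl)ccc1-n1cnnn1)[C@@H]1CC=NN1C(=O)[C@H](O)c1ccccc1F` gives 8.9 10^-6 cm/s. Compound 3 `CC(C)(C)[C@@H](O)C(=O)N1[C@@H]2C[C@@H]2C[C@H]1C(=O)NCc1cc(Cl)ccc1-n1cnnn1` gives 34 10^-6 cm/s. On these numbers compound 2 stands second highest of the three: compound 3 sits nearest, with a number that is beyond the scatter above it, and compound 1 sits furthest, with a number that is beyond the scatter below it. For the measured compounds named here, none of these three pairs differ in only one place, so no single structural step between measured compounds can be read off.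

Compound 4 `O=C(NCc1cc(Cl)ccc1-n1cnnn1)[C@@H]1CC=NN1C(=O)[C@H](O)C1CCCCC1` is the unmeasured partner of compound 2. It differs in one place: cyclohexyl in place of 2-fluorophenyl on a saturated chain carbon bound to a carbonyl carbon and an oxygen on a saturated carbon. The change keeps the count of hydrogen-bond donors and acceptors the same and trades an aromatic six-membered ring for a non-aromatic one of the same size.

Going by the values given here, with no measured step of this kind to lean on, the expected step in this assay is small and, if anything, upward: a 1.3-fold higher number from compound 2 to compound 4 (0.13 log units; within the scatter) is the estimated step from compound 2 to compound 4. Compound 4 is therefore expected to give about 12 10^-6 cm/s, with a range from 5 10^-6 cm/s to 30 10^-6 cm/s.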

Compound 4, apparent permeability: 19 10^-6 cm/s
Compound 4: the middle estimate sits 1.6-fold (0.20 log units) below what was measured; the measured number falls inside the stated range.
By their numbers in this assay, from the lowest: compound 1; then compound 2; then compounds 4 and 3 (each within the scatter of the next).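

For the compounds shown here, this is the first step that differs in one place, so it gives a direct reading of this position: in this assay, cyclohexyl in place of 2-fluorophenyl on a saturated chain carbon bound to a carbonyl carbon and an oxygen on a saturated carbon gives a 2.1-fold higher number from compound 2 to compound 4 (0.33 log units; beyond the scatter), a modest step. On this single pair, then, an aromatic ring at this place is not required to reach the higher number, and a non-aromatic ring of the same size, carrying no fluorine, serves at least as well on this read-out. Nothing available here explains why the number moved, so the step stands as an observation only.

The fluorine and the aromatic ring leave together in this one change, so the compounds shown cannot say which of the two matters, and a plain phenyl at this place would separate them. Also open, from the compounds shown here alone, is how a cyclohexyl ring carrying an amine or a carboxylic acid would read here, and whether the same swap gives a similar step on the core of compound 1.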